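The source may hold more compounds than are shown below. What is called first, only, known or untested is meant among the compounds shown, and "the series" means these compounds.

Compound 1, `CCOC(=O)C(=Cc1c(-c2ccccc2)[nH]c2ccccc12)C(=O)OCC`: 10300 nM
Compound 2, `COc1ccc(-c2[nH]c3ccc(OC)cc3c2/C=C(\C#N)S(=O)(=O)c2ccccc2)cc1`: 4200 nM
Compound 3, `CC(=O)/C(=C\c1c(-c2ccccc2)[nH]c2ccccc12)S(=O)(=O)c1ccccc1`: 2400 nM

All three were tested in a functional assay on CAKI-1 cells (Homo sapiens) for inhibition, read by sulforhodamine B assay, with a stated time of 48 h; on this read-out lower numbers stand for stronger inhibition of growth and higher numbers for weaker inhibition of growth. Compound 3 gives the lowest of the three numbers; its gap to compound 2 lies within the usual scatter of repeated measurements, while its gap to compound 1 lies beyond it. Compound 4, `N#C/C(=C\c1c(-c2ccccc2)[nH]c2ccccc12)S(=O)(=O)c1ccccc1`, is not yet measured. It differs from compound 3 in one place: cyano in place of acetyl on a double-bonded chain carbon bound to a double-bonded chain carbon and a sulfonyl sulfur. Among the compounds with values here, no measured pair differs in exactly this way, so no directly matching step exists. Compound 2 also carries a cyano on a double-bonded chain carbon bound to a sulfonyl sulfur, and in this assay compound 2 gives 4200 nM, close to compound 3. The step of a 1.3-fold higher number from compound 3 to compound 4 (0.10 log units; within the scatter) is therefore expected to be of no size beyond the scatter, in either direction. The estimate for compound 4 in this assay is 3000 nM, with a range from 1000 nM to 9000 nM.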

Compound 4, concentration for 50% growth inhibition: 5500 nM
Estimate against measurement, compound 4: 1.8-fold (0.26 log units) below; measured number inside the range.
By their numbers in this assay, from the lowest: compounds 3, 2, 4 and 1 (each within the scatter of the next, the first and the last beyond it).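

Cyano in place of acetyl on this double-bonded chain carbon gives a 2.3-fold higher number from compound 3 to compound 4 (0.36 log units; beyond the scatter) in this assay, the first change at this place that can be read on its own. The place is therefore not indifferent to its group: acetyl gives the lower number, and so the stronger inhibition of growth, though the step is modest. Nothing measured on these compounds explains the step.

Open, from the compounds shown here alone, is how a carboxylic acid or an amide would behave in this place. Also open, going by these compounds, is whether the same step would appear on the core of compound 2.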